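The source may hold more compounds than are shown below. What is called first, only, known or untested is meant among the compounds shown, and "the series" means these compounds.

Values in an ADME assay on HEL cells (Homo sapiens) for cytotoxicity; on this read-out lower numbers stand for higher toxicity in this test and higher numbers for lower toxicity in this test:
- Compound 1 `C/C=C/c1ccccc1-c1cc2cn([C@H]3C[C@H](O)[C@@H](CO)O3)c(=O)nc2o1`: 103000 nM
- Compound 2 `C/C=C/c1cccc(-c2cc3cn([C@H]4C[C@H](O)[C@@H](CO)O4)c(=O)nc3o2)c1`: > 200000 nM, a limit of the assay and not a number
- Compound 3 `CC/C=C/c1cccc(-c2cc3cn([C@H]4C[C@H](O)[C@@H](CO)O4)c(=O)nc3o2)c1`: 68000 nM

Compound 3 lies within the scatter of compound 1, and the only other entry is the limit for compound 2.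

Compound 4 `CCC/C=C/c1cccc(-c2cc3cn([C@H]4C[C@H](O)[C@@H](CO)O4)c(=O)nc3o2)c1` lengthens the chain of compound 3, from but-1-en-1-yl to pent-1-en-1-yl: methyl in place of hydrogen on a saturated chain carbon, two bonds along the chain from a double-bonded chain carbon. This places methyl in place of hydrogen on a saturated chain carbon, two bonds along the chain from a double-bonded chain carbon.

Among the measured compounds shown here, the closest precedent is an at least 2.9-fold lower number from compound 2 to compound 3 (0.46 log units; beyond the scatter), where methyl replaced hydrogen on a saturated chain carbon bound to a double-bonded chain carbon. Its size is only a floor, since it starts from a limit. The step of an at least 1.9-fold higher number from compound 1 to compound 2 (0.28 log units; that floor lies within the scatter) is a different change and offers no guide. One step sets no trend, so only a small further fall in this assay is expected, resting on compound 3 and an at least 2.9-fold lower number from compound 2 to compound 3 (0.46 log units; beyond the scatter). The expected change is a 1.6-fold lower number from compound 3 to compound 4 (0.21 log units; within the scatter).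

For compound 4 the estimate is 42000 nM, with an expected range from 18000 nM to 90000 nM.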

Compound 4, half-maximal cytotoxic concentration: > 200000 nM
Compound 4 ended at the assay's limit; the forecaster's own chance of this, stated with the estimate: 3%; at least 4.7-fold (0.67 log units) between middle value and limit.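

In this assay, the lengthening from but-1-en-1-yl to pent-1-en-1-yl runs against the earlier step on this chain: an at least 2.9-fold higher number from compound 3 to compound 4 (0.46 log units; beyond the scatter), whereas the previous methyl for hydrogen gave an at least 2.9-fold lower number from compound 2 to compound 3 (0.46 log units; beyond the scatter). The same change therefore does not move the read-out in one direction along this chain, and compound 3 is the only one of the three chain lengths that gives a number rather than a limit. Compound 2 and compound 4 both end at a limit, so the step between them cannot be read: the limit of > 200000 nM in this assay, at which 2 of the 4 values shown sit.

As far as these compounds go, whether a longer chain such as hex-1-en-1-yl would also end at the limit stays open. From the compounds shown here alone, how a hydroxyl or an amine at the end of the chain would read in this assay is equally open.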